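The source may report more compounds than this note shows. Statements on the series, on what has been measured and on what is new or still open speak of the compounds shown alone.

Three compounds of one family carry a shared core, and the measurement is made in a functional assay on L1210 cells (Mus musculus) for inhibition, read by cell counting, with a stated time of 2 days; a higher number here means a weaker inhibitor, a lower number a stronger inhibitor. Compound 1 `CCOc1ccc(-c2nn3cc(-c4cccc(N)c4)nc3s2)cc1` gives 155000 nM in this assay. Compound 2 `Nc1cccc(-c2cn3nc(Cc4ccccc4)sc3n2)c1` gives 7400 nM in this assay. For compound 3 `COc1cccc(-c2nn3cc(-c4cccc(N)c4)nc3s2)c1` this assay returns only a limit, > 250000 nM, and not a number. So compound 3 stands at the edge of what this assay can report, namely (the limit of > 250000 nM in this assay, at which 1 of the 3 values shown sits); how far beyond that edge it lies is unknown. The next step leads to compound 4 `Nc1cccc(-c2cn3nc(-c4ccccc4)sc3n2)c1`, which differs from compound 3 by hydrogen in place of methoxy on an aromatic carbon. Going by the values given here, no pair of measured compounds differs in just one place, so no measured step shows what such a change does here. With the starting value itself only a limit, the expected size of the step from compound 3 to compound 4 in this assay is uncertain, and the expectation is that it falls within the scatter or moves modestly toward a stronger inhibitor, an at least 2.0-fold lower number from compound 3 to compound 4 (0.31 log units; beyond the scatter). Compound 4 is therefore estimated at 120000 nM, with a range from 30000 nM to 400000 nM, and a real chance that this assay again reports only a limit.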

Compound 4, half-maximal inhibitory concentration: 32000 nM
Compound 4: the middle estimate sits 3.8-fold (0.57 log units) above what was measured, and the stated range covers the measured number.
By their numbers in this assay, from the lowest: compound 2; then compound 4; then compound 1. At a limit, above all of these: compound 3.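

In this assay compound 3 reads > 250000 nM, which is a limit and not a number, so the step from it can only be given as a minimum: the limit of > 250000 nM in this assay, at which 1 of the 4 values shown sits.
Hydrogen in place of methoxy on an aromatic carbon gives an at least 7.8-fold lower number from compound 3 to compound 4 (0.89 log units; beyond the scatter) and hydrogen in place of ethoxy gives a 4.8-fold lower number from compound 1 to compound 4 (0.69 log units; beyond the scatter), so in both of these pairs the ring without the added group is the stronger inhibitor.
Phenyl in place of benzyl moves the other way and gives a 4.3-fold higher number from compound 2 to compound 4 (0.64 log units; beyond the scatter), so keeping the benzyl group of compound 2 is the better of these two options.

The compounds shown leave open whether a hydroxyl or a chlorine on that aromatic carbon would read closer to hydrogen or to methoxy, and whether a phenylethyl chain in place of benzyl would lower the number further.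
They also do not show why these changes move the number.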